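Notes on the amide change from compound 2 to compound 3

The source may hold more compounds than are shown below. What is called first, only, known or untested is meant among the compounds shown, and "the series" means these compounds.

Compound 1 `COCC(=O)Nc1c(C(O)(C(F)(F)F)C(F)(F)F)ccc2ccccc12` and compound 2 `Cc1cccc(C(=O)Nc2c(C(O)(C(F)(F)F)C(F)(F)F)ccc3ccccc23)c1` share one core and differ only in the group on the carbonyl carbon. For the measured compounds named here, in an assay on LtK cells with ATP-sensitive inward rectifier potassium channel 11 (Homo sapiens) as the target (a higher number here means that more compound is needed for the effect, a lower number that less compound is needed), compound 1 gives 213 nM, and compound 2 gives 23 nM; the step of a 9.3-fold lower number from compound 1 to compound 2 (0.97 log units; beyond the scatter) is the only measured step in the set. Compound 2 thus holds the lowest number of the two measured, with compound 1 the nearest at a clearly higher value.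

Compound 3 `O=C(Nc1c(C(O)(C(F)(F)F)C(F)(F)F)ccc2ccccc12)c1ccc(C(F)(F)F)cc1` is not yet measured. It differs from compound 2 as follows: 4-(trifluoromethyl)phenyl in place of 3-methylphenyl on a carbonyl carbon. Going by the values given here, the one measured step replaces methoxymethyl with a substituted phenyl, whereas here one substituted phenyl is exchanged for another; that step bears only loosely on this change, and no measured pair makes such an exchange. The expectation for compound 3 in this assay is therefore a step of a 1.3-fold higher number from compound 2 to compound 3 (0.12 log units; within the scatter) that stays within the scatter. Compound 3 is estimated at 30 nM, with a range from 8 nM to 110 nM.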

Compound 3, half-maximal effective concentration: 160 nM
The estimate for compound 3 lay 5.3-fold (0.73 log units) below the measured number, and the stated range ends below it.
By their numbers in this assay, from the lowest: compound 2; then compounds 3 and 1 (each within the scatter of the next).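

At this position on the carbonyl carbon, swapping one substituted phenyl for another is not a neutral exchange in this assay: the result is a 7.0-fold higher number from compound 2 to compound 3 (0.84 log units; beyond the scatter). A phenyl ring alone therefore does not set the number, since the change from methoxymethyl to 4-(trifluoromethyl)phenyl gives a 1.3-fold lower number from compound 1 to compound 3 (0.12 log units; within the scatter), and only 3-methylphenyl stands clearly apart among the three groups. No measured evidence accounts for this difference between the two phenyl groups.

The two phenyl groups differ in both the substituent and its printed ring number, so the compounds shown cannot say which of these matters. The 4-methylphenyl and 3-(trifluoromethyl)phenyl amides would separate the two, while the unsubstituted phenyl amide would give the baseline for both.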